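Adding a Third Fluoro at the Assay Limit

The compounds below may be only part of what the source reports. "The series", "measured", "known", "first", "only" and "open" are said of these compounds alone.

- compound 1 `CC(C)[C@H](NC(=O)COc1cccc2ccccc12)C(=O)N[C@@H](CC(=O)O)C(=O)COc1ccccc1F` gives > 100000 nM (a limit)
- compound 2 `CC(C)[C@H](NC(=O)COc1cccc2ccccc12)C(=O)N[C@@H](CC(=O)O)C(=O)COc1ccc(F)cc1` gives > 100000 nM (a limit)
- compound 3 `CC(C)[C@H](NC(=O)COc1cccc2ccccc12)C(=O)N[C@@H](CC(=O)O)C(=O)COc1cc(F)ccc1F` gives > 100000 nM (a limit)

These results come from a functional assay on Jurkat cells (Homo sapiens) (on this read-out lower numbers stand for stronger inhibition and higher numbers for weaker inhibition), where the picture is simple: the limit of > 100000 nM in this assay, at which 3 of the 3 values shown sit. Compound 3 therefore has no actual number, only its limit of > 100000 nM, and it cannot be ranked against the other two.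

Compound 4 `CC(C)[C@H](NC(=O)COc1cccc2ccccc12)C(=O)N[C@@H](CC(=O)O)C(=O)COc1c(F)ccc(F)c1F` carries one change, (fluoro in place of hydrogen on an aromatic carbon), which turns 2,5-difluorophenyl into 2,3,6-trifluorophenyl: fluoro in place of hydrogen on an aromatic carbon. The nearest precedents are a step that the two limits leave unreadable from compound 1 to compound 3 and a step that the two limits leave unreadable from compound 2 to compound 3, and moving the fluoro gives a step that the two limits leave unreadable from compound 1 to compound 2 as well. None of these has a size that can be carried over, and none gives a direction.

The expected a number no higher from compound 3 to compound 4 (the limit leaves the size open) is thus no readable shift, though a measurable value cannot be ruled out. Compound 4 is expected at 100000 nM (estimated range 5000 nM to 200000 nM).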

Compound 4, half-maximal inhibitory concentration: 1200 nM
Estimate against measurement, compound 4: 83-fold (1.92 log units) above; measured number outside the range, below it.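

In this assay, among the compounds shown here, a single added fluoro, turning 2,5-difluorophenyl into 2,3,6-trifluorophenyl, gives an at least 83-fold lower number from compound 3 to compound 4 (1.92 log units; beyond the scatter), and this is the first change with a readable effect. Measured against the two singly fluorinated phenyl groups, the 2,3,6-trifluorophenyl group gives an at least 83-fold lower number from compound 2 to compound 4 (1.92 log units; beyond the scatter) and an at least 83-fold lower number from compound 1 to compound 4 (1.92 log units; beyond the scatter), while the steps among the three earlier compounds cannot be read. These sizes are only minimums, because the earlier compounds give no actual number: the limit of > 100000 nM in this assay, at which 3 of the 4 values shown sit.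

The compounds shown leave open whether this aromatic carbon needs a fluoro specifically, or whether a chloro or methyl group in the same place would also give measurable inhibition. They also do not show whether a third fluoro elsewhere on the ring would have the same effect.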